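This account rests on a few compounds, and the source may have more. Where it says the series, first, only, none or still open, it means among the compounds named here.

Compound 1 `CC(C(=O)NCc1ccc(C(F)(F)F)nc1-c1ccc(C(C)(C)C)cc1)c1ccc(NS(C)(=O)=O)c(F)c1` gives 0.5 nM in an assay on CHO cells for antagonist activity at transient receptor potential cation channel subfamily V member 1 (Homo sapiens), read by FLIPR; on this read-out higher numbers stand for weaker inhibition and lower numbers for stronger inhibition. Compound 2 `CC(C(=O)NCc1ccc(C(F)(F)F)nc1-c1ccc(F)c(Cl)c1)c1ccc(NS(C)(=O)=O)c(F)c1` gives 0.2 nM. Compound 3 `COc1ccc(-c2nc(C(F)(F)F)ccc2CNC(=O)C(C)c2ccc(NS(C)(=O)=O)c(F)c2)cc1F` gives 4.2 nM.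

Compound 2 shows the lowest number of the three: a 2.5-fold lower number from compound 1 to compound 2 (0.40 log units; beyond the scatter) and a 21-fold higher number from compound 2 to compound 3 (1.32 log units; beyond the scatter), so its nearest neighbour is compound 1 and its furthest is compound 3. Compound 4 `CC(C(=O)NCc1ccc(C(F)(F)F)nc1CCc1ccc(F)cc1)c1ccc(NS(C)(=O)=O)c(F)c1` differs from compound 2 at one place: 2-(4-fluorophenyl)ethyl in place of 3-chloro-4-fluorophenyl on an aromatic carbon. Within the data shown here, the two steps that alter this same place, a 2.5-fold lower number from compound 1 to compound 2 (0.40 log units; beyond the scatter) and a 21-fold higher number from compound 2 to compound 3 (1.32 log units; beyond the scatter), show that exchanging the group here moves the number by modest to large amounts, and none of the measured compounds carries a chain-linked ring here. A higher number is therefore expected for compound 4, with a step of a 25-fold higher number from compound 2 to compound 4 (1.40 log units; beyond the scatter). The estimate for compound 4 is 5 nM, with a range from 1 nM to 30 nM.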

Compound 4, inhibition constant: 1.8 nM
Estimate against measurement, compound 4: 2.8-fold (0.44 log units) above; the measured number falls inside the stated range.
By their numbers in this assay, from the lowest: compound 2; then compound 1; then compound 4; then compound 3.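

The ring need not sit directly on the core: 2-(4-fluorophenyl)ethyl falls within the span set by the directly attached rings. It gives up ground to 3-chloro-4-fluorophenyl (a 9.0-fold higher number from compound 2 to compound 4 (0.95 log units; beyond the scatter)) and to 4-(tert-butyl)phenyl (a 3.6-fold higher number from compound 1 to compound 4 (0.56 log units; beyond the scatter)), yet improves on 3-fluoro-4-methoxyphenyl (a 2.3-fold lower number from compound 3 to compound 4 (0.37 log units; beyond the scatter)). No evidence here explains why this position accepts the chain.

Still open, going by these compounds, is how the number responds to the length of the link, as with a benzyl or 3-(4-fluorophenyl)propyl group. Also open, on these data alone, is whether a 2-(3-chloro-4-fluorophenyl)ethyl group would bring it closer to compound 2.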